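The Ring Nitrogen Substituent Changed to Allylcarbamoyl

The source may hold more compounds than are shown below. What is called first, only, known or untested is meant among the compounds shown, and "the series" means these compounds.

Compound 1 `COc1ccc(-c2cc(=O)c3c(OC)cc(OC)cc3[nH]2)cc1` carries a hydrogen on its ring nitrogen. In a functional assay on KOPN-8 cells (Homo sapiens) for antiproliferative activity, with a stated time of 72 h (a higher number here means that more compound is needed for the effect, a lower number that less compound is needed), compound 1 is recorded only as a limit, > 31100 nM. Compound 2 `COc1ccc(-c2cc(=O)c3c(OC)cc(OC)cc3n2C)cc1` has a methyl on that nitrogen, and in this assay compound 2 gives 30000 nM; the step of an at least 1.0-fold lower number from compound 1 to compound 2 (0.01 log units; that floor lies within the scatter) stays within the scatter. Compound 3 `COc1ccc(-c2cc(=O)c3c(OC)cc(OC)cc3n2Cc2ccccc2)cc1` bears a benzyl on the same nitrogen, and in this assay compound 3 is again recorded only as a limit, > 17300 nM. Among the compounds with values here, compound 3 therefore stands at one of two limits among the three measured compounds, with compound 2 the only one that gives a number. The steps a step that the two limits leave unreadable from compound 1 to compound 3 and a step that the limit leaves unreadable from compound 2 to compound 3 cannot be sized because the limit of > 17300 nM in this assay, at which 1 of the 3 values shown sits, and the limit of > 31100 nM in this assay, at which 1 of the 3 values shown sits, cap them.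

Compound 4 `C=CCNC(=O)n1c(-c2ccc(OC)cc2)cc(=O)c2c(OC)cc(OC)cc21` differs from compound 3 by allylcarbamoyl in place of benzyl on an aromatic nitrogen. Within the data shown here, no measured step bears directly on this change; the three measured compounds show only that hydrogen, methyl and benzyl on the ring nitrogen all leave the compounds weak in this assay. The step that the limit leaves unreadable from compound 3 to compound 4 is therefore expected to be none beyond the scatter, in no fixed direction. Compound 4 is estimated at 25000 nM, with a range from 8000 nM to 80000 nM, and a limit rather than a number is expected to be the likely outcome.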

Compound 4, half-maximal effective concentration: 12000 nM
Beside the measured number, compound 4's estimate is 2.1-fold (0.32 log units) above it; the range from low to high includes it.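

Of the four compounds, compound 4 alone separates from the others by more than the scatter in this assay: allylcarbamoyl on the aromatic nitrogen gives a 2.5-fold lower number from compound 2 to compound 4 (0.40 log units; beyond the scatter), and an at least 2.5-fold lower number from compound 1 to compound 4 (0.41 log units; beyond the scatter), whereas the step from hydrogen to methyl at this position stayed within the scatter. Against benzyl, the same change gives an at least 1.4-fold lower number from compound 3 to compound 4 (0.15 log units; that floor lies within the scatter), which is a floor and not a full size, so the comparison with compound 3 does not yet show a change beyond the scatter. That step can be given only as a floor because compound 3 is recorded only as a limit: the limit of > 17300 nM in this assay, at which 1 of the 4 values shown sits.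

The compounds shown leave open which part of allylcarbamoyl goes with the lower number, the terminal allyl or the carbamoyl carbonyl and its amide hydrogen, and a propylcarbamoyl or an acetyl on the same nitrogen would separate the two. Also open, from the compounds shown here alone, is whether a longer chain on the carbamoyl nitrogen, or an amine at the end of such a chain, would take the number lower still in this assay.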